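The compounds below may be only part of what the source reports. "The series", "measured", "known", "first", "only" and "open" are said of these compounds alone.

Working notes on the series.

The series is read in a functional assay on HT-29 cells (Homo sapiens) for antiproliferative activity, read by MTT assay, with a stated time of 72 h; on this read-out lower numbers stand for stronger inhibition and higher numbers for weaker inhibition. Compound 1 `COc1cc2c(Oc3ccc(NC(=O)c4nc(-c5ccc(F)cc5)no4)cc3)ccnc2cc1OCCCN1CCC(C)CC1` gives 6380 nM and stands highest of the three numbers on hand. Within the data shown here, compound 2 `COc1cc2c(Oc3ccc(NC(=O)C4(c5nnc(-c6ccc(F)cc6)o5)CC4)cc3F)ccnc2cc1OCCCN1CCCC1` gives 779 nM and compound 3 `COc1cc2c(Oc3ccc(NC(=O)C4(c5nnc(-c6ccc(F)cc6)o5)CC4)cc3F)ccnc2cc1OCCCN1CCC(C)CC1` gives 442 nM; both carry a 5-(4-fluorophenyl)-1,3,4-oxadiazol-2-yl group, but each also differs from compound 1 in more than one place, so no single step from compound 1 to either of them is defined. Among the measured compounds shown here, the only measured step, a 1.8-fold lower number from compound 2 to compound 3 (0.25 log units; within the scatter), concerns the amine on the chain and does not touch the heteroaryl group.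

Compound 4 `COc1cc2c(Oc3ccc(NC(=O)c4nnc(-c5ccc(F)cc5)o4)cc3)ccnc2cc1OCCCN1CCC(C)CC1` differs from compound 1 by 5-(4-fluorophenyl)-1,3,4-oxadiazol-2-yl in place of 3-(4-fluorophenyl)-1,2,4-oxadiazol-5-yl on a carbonyl carbon. For the measured compounds named here, no measured step bears directly on this change. What the values of compound 2 and compound 3 show is that compounds carrying the entering oxadiazole give lower numbers than compound 1, though other changes accompany that. On this basis a moderate move toward lower numbers is expected, with wide uncertainty. For compound 4 the estimate is 3000 nM, with a range from 800 nM to 10000 nM, corresponding to an expected step of a 2.1-fold lower number from compound 1 to compound 4 (0.33 log units; beyond the scatter).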

Compound 4, half-maximal inhibitory concentration: 7890 nM
For compound 4 the middle estimate is 2.6-fold (0.42 log units) below the measured one; the measured number falls inside the stated range.
By their numbers in this assay, from the lowest: compounds 3 and 2 (each within the scatter of the next); then compounds 1 and 4 (each within the scatter of the next).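

In this assay the exchange on a carbonyl carbon, 5-(4-fluorophenyl)-1,3,4-oxadiazol-2-yl in place of 3-(4-fluorophenyl)-1,2,4-oxadiazol-5-yl, gives (a 1.2-fold higher number from compound 1 to compound 4 (0.09 log units; within the scatter)), so at this position, on the core of compound 1, this read-out does not separate the two groups, which have the same atoms joined differently. The entering group alone therefore does not account for the printed values of compound 2 (779 nM) and compound 3 (442 nM), since compound 4 carries the same group and gives (7890 nM). No measured evidence on these two groups is available to explain this result.

Among these compounds, compound 2 and compound 3 still differ from compound 4 in more than one place, and no step shows which of those differences goes with their lower numbers. From the compounds shown here alone, it also remains open whether a 5-phenyl-1,3,4-oxadiazol-2-yl group without the fluorine, or a 5-(4-chlorophenyl)-1,3,4-oxadiazol-2-yl group, on the same carbonyl carbon would read any differently from the two groups compared here.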